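The source may hold more compounds than are shown below. What is called first, only, known or untested is meant among the compounds shown, and "the series" means these compounds.

Measured so far:
compound 1 `CN1CCN(c2ccc(Nc3ncc4nc(Nc5ccc(F)cc5)n([C@H]5CCCN(S(=O)(=O)C6CC6)C5)c4n3)cc2)CC1` — 1320 nM
compound 2 `CN1CCN(c2ccc(Nc3ncc4nc(Nc5ccc(F)cc5)n([C@@H]5CCCC(NC(=O)OC(C)(C)C)C5)c4n3)cc2)CC1` — "not determined" (no result reported)

Going by the values given here, in a functional assay on A549 cells (Homo sapiens) for antiproliferative activity, read by MTT assay, with a stated time of 72 h (on this read-out lower numbers stand for stronger inhibition and higher numbers for weaker inhibition), compound 1 gives 1320 nM, the only number in the set; compound 2 carries no value, so compound 1 stands alone as the reference. Compound 3 `CN1CCN(c2ccc(Nc3ncc4nc(Nc5ccc(F)cc5)n(-c5cccc(NC(=O)CO)c5)c4n3)cc2)CC1` differs from compound 1 in one place: 3-(((hydroxymethyl)carbonyl)amino)phenyl in place of 1-(cyclopropylsulfonyl)piperidin-3-yl on an aromatic nitrogen. Among the compounds with values here, no step between measured compounds exists to calibrate this change, so the expectation rests on compound 1 only. The step of a 1.5-fold lower number from compound 1 to compound 3 (0.17 log units; within the scatter) is expected to stay within the usual scatter, with no clear direction. Compound 3 is therefore estimated at 900 nM in this assay, with a range from 250 nM to 3500 nM.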

Compound 3, half-maximal inhibitory concentration: 1510 nM
Beside the measured number, compound 3's estimate is 1.7-fold (0.22 log units) below it; low and high end bracket the measured number.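

In this assay the exchange gives a 1.1-fold higher number from compound 1 to compound 3 (0.06 log units; within the scatter) and so shows that this aromatic nitrogen can carry 3-(((hydroxymethyl)carbonyl)amino)phenyl in place of 1-(cyclopropylsulfonyl)piperidin-3-yl without a readable change. A six-membered aromatic ring of carbon only, with no defined stereocentre and 2 hydrogen-bond donors, therefore reads level with the sulfonylated piperidine. No measurement at hand bears on the reason for this result.

Still open, on these data alone, is whether a carboxylic acid or a free amine in place of the (hydroxymethyl)carbonyl amino group would move the number beyond the scatter.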